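A few compounds are considered here, and "the series" means these few. Any claim that something is new, unique, unknown or untested is made for them only; others in the source may bear on it.

Measured in a functional assay on HL-60 cells (Homo sapiens) for inhibition, read by CCK-8 assay, with a stated time of 48 h; on this read-out lower numbers stand for stronger inhibition and higher numbers for weaker inhibition:

compound 1, `O=C(NCCNS(=O)(=O)c1ccc(-c2ccccc2Oc2ccc(O)c(O)c2)s1)Nc1cc(Cl)cc(Cl)c1`: 10400 nM
compound 2, `O=C(NCCNS(=O)(=O)c1ccc(-c2ccccc2OCc2ccccc2)s1)Nc1cc(Cl)cc(Cl)c1`: 11700 nM
compound 3, `O=C(NCCNS(=O)(=O)c1ccc(-c2ccccc2Oc2ccc(O)c(O)c2)s1)Nc1cc(C(F)(F)F)cc(C(F)(F)F)c1`: 10500 nM

All three numbers lie within the scatter of one another, so no order among them is claimed. Compound 1 and compound 2 differ in one place, (benzyl in place of 3,4-dihydroxyphenyl on an oxygen on an aromatic ring), and that change made a 1.1-fold higher number from compound 1 to compound 2 (0.05 log units; within the scatter). Compound 3 carries a different core; the difference between the core of compound 1 and the core of compound 3 is not broken down here, and the two values alone show no separation.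

Compound 4, `O=C(NCCNS(=O)(=O)c1ccc(-c2ccccc2OCc2ccccc2)s1)Nc1cc(C(F)(F)F)cc(C(F)(F)F)c1`, has not yet been measured. It differs from compound 3 by benzyl in place of 3,4-dihydroxyphenyl on an oxygen on an aromatic ring. The place of the change is the same, word for word, as in the pair compound 1 to compound 2, so this is the same change on the second core. The expected step from compound 3 to compound 4 in this assay is a 1.1-fold higher number from compound 3 to compound 4 (0.04 log units; within the scatter), set beside the earlier step of a 1.1-fold higher number from compound 1 to compound 2 (0.05 log units; within the scatter) and resting on the value of compound 3, 10500 nM. On that basis compound 4 is estimated at 11500 nM, with an expected range from 6000 nM to 23000 nM.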

Compound 4, half-maximal inhibitory concentration: 11400 nM
Compound 4: middle estimate off by 1.0-fold (0.00 log units), on the high side, within the range that was stated.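

In this assay the swap of 3,4-dihydroxyphenoxy to benzyloxy on the second core gives a 1.1-fold higher number from compound 3 to compound 4 (0.04 log units; within the scatter), and the two steps can be set side by side: the same change on two cores in this assay, a 1.1-fold higher number (0.05 log units; within the scatter) from compound 1 to compound 2 and a 1.1-fold higher number (0.04 log units; within the scatter) from compound 3 to compound 4, 1.0-fold (0.02 log units) apart, within the scatter of two such steps. The change therefore carries from the core of compound 1 to the core of compound 3 with no separable difference, and on neither core does it move the number beyond the scatter. Among these compounds, this rests on only two cores and one cell read-out, and since both steps are small, it shows agreement between two near-null results, not that a change with a step beyond the scatter would transfer in the same way.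

Still open, going by these compounds, is whether an amine or a carboxylic acid on that oxygen, in place of benzyl or 3,4-dihydroxyphenyl, would separate from these four compounds in this assay. Also open, on these data alone, is whether the same agreement between steps would hold on a core with a longer chain in place of the ethylene chain shared by all four compounds.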